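Chalcone series: methyl added to the benzoyl ring

A few compounds are considered here, and "the series" means these few. Any claim that something is new, unique, unknown or untested is made for them only; others in the source may bear on it.

Going by the values given here, compound 1 `O=C(/C=C/c1cc(F)cc(F)c1O)c1ccccc1` is one of two compounds measured in a functional assay on MCF7 cells (Homo sapiens) for antiproliferative activity, read by sulforhodamine B assay, with a stated time of 72 h, tested at 30 uM; a higher number here means a weaker effect of the compound at the concentration tested, a lower number a stronger effect; in this assay compound 1 gives 37.6%. The other measured compound, compound 2 `O=C(/C=C/c1cc(Br)ccc1O)c1ccc(Br)cc1`, gives 28.3% in this assay. Among the compounds with values here, the gap between the two numbers lies within the scatter of the method, so compound 1 and compound 2 cannot be told apart on the readings available, and no step between measured compounds that differ in one place has been recorded.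

Compound 3 `Cc1ccc(C(=O)/C=C/c2cc(F)cc(F)c2O)cc1` is to be measured in this assay. The difference from compound 1 to compound 3 is methyl in place of hydrogen on an aromatic carbon, the methyl sitting on an aromatic carbon of the six-membered aromatic ring of carbon only, para to a large group. Within the data shown here, no measured pair shows what a methyl in this place does, so the expectation rests on compound 1 alone. A step from compound 1 to compound 3 of no more than the scatter, in either direction, is expected, a number 4.6 percentage points lower from compound 1 to compound 3 (within the scatter). For compound 3 the estimated reading is 33%, with a range from 15% to 52%.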

Compound 3, a percentage reported as activity, at one concentration (the size of the read-out at that concentration, not a potency): 35.3%
The estimate for compound 3 lay 2.3 percentage points below the measured number; measured number inside the range.
By their numbers in this assay, from the lowest: compounds 2, 3 and 1 (each within the scatter of the next).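

Going by these compounds alone, this is the first one-place pair: in this assay, methyl in place of hydrogen on an aromatic carbon, para to a large group, gives a number 2.3 percentage points lower from compound 1 to compound 3 (within the scatter). The benzoyl ring thus accepts a methyl at this position with no reading that can be told apart from that of compound 1, so at the single concentration tested this small carbon substituent neither adds to nor takes away from the effect by a measurable amount. No measurement of any property of these compounds accompanies the result, so the data offer no explanation for it.

As far as these compounds go, whether this tolerance is specific to methyl remains open: a longer chain such as propyl, a methoxy group, an amine or a carboxylic acid at the same position could still move the reading beyond the scatter. Also open, from the compounds shown here alone, is whether methyl behaves the same way on a compound with other ring substituents, such as the bromine-bearing compound 2, and whether a full concentration-response comparison would separate compound 1 from compound 3.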